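The source may hold more compounds than are shown below. What is called first, only, known or untested is meant among the compounds shown, and "the series" means these compounds.

Three compounds that share one core were tested in an ADME assay on RAW264.7 cells (Mus musculus) for cytotoxicity, read by MTT assay, with a stated time of 24 h, in the absence of a further agent; on this read-out higher numbers stand for weaker inhibition and lower numbers for stronger inhibition. Compound 1, `CCC(C)Oc1ccc(C(O)C2OC(=O)c3c(OC)cc(OC)cc32)cc1`, gives > 40000 nM in this assay, which is a limit of the assay rather than a number. Compound 2, `CCOCCOc1ccc(C(O)C2OC(=O)c3c(OC)cc(OC)cc32)cc1`, carries 2-ethoxyethyl in place of sec-butyl on an oxygen on an aromatic ring and gives > 40000 nM, again a limit. Compound 3, `COc1cc(OC)c2c(c1)C(C(O)c1ccc(OCCOc3ccccc3)cc1)OC2=O`, carries 2-phenoxyethyl in place of sec-butyl on an oxygen on an aromatic ring and gives > 40000 nM, also a limit. Because all three values sit at the limit of > 40000 nM in this assay, at which 3 of the 3 values shown sit, the steps a step that the two limits leave unreadable from compound 1 to compound 2, a step that the two limits leave unreadable from compound 1 to compound 3 and a step that the two limits leave unreadable from compound 2 to compound 3 cannot be sized, and compound 3 therefore stands at the same limit as the other two, with no number to set it apart.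

Compound 4, `COc1cc(OC)c2c(c1)C(C(O)c1ccc(OCc3ccc(OC(F)F)cc3)cc1)OC2=O`, has not yet been measured. It differs from compound 3 by 4-(difluoromethoxy)phenyl in place of phenoxymethyl on a saturated chain carbon bound to an oxygen on an aromatic ring. The measured steps that bear on this change, a step that the two limits leave unreadable from compound 1 to compound 3 and a step that the two limits leave unreadable from compound 2 to compound 3, both exchange groups on the same side chain, and both were left unreadable by the limits, so they offer neither a size nor a direction to expect. The step that the limit leaves unreadable from compound 3 to compound 4 is therefore expected to remain hidden at the limit. Compound 4 is estimated to give 50000 nM, within 20000 nM to 120000 nM, and most likely to be reported only as a limit.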

Compound 4, half-maximal inhibitory concentration: > 40000 nM
Compound 4 ended at the assay's limit; the forecaster's own chance of this, stated with the estimate: 85%; the middle value lies beyond the limit too.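

Compound 4 gives > 40000 nM in this assay and this is a limit, not a number. Going by these compounds alone, no step among compound 1, compound 2, compound 3 and compound 4 can be read, because all four sit at the same limit: the limit of > 40000 nM in this assay, at which 4 of the 4 values shown sit. The compounds shown leave open how far apart their cytotoxicity lies, and whether any side chain on the shared core would give a measurable value.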